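This account rests on a few compounds, and the source may have more. Where it says the series, first, only, none or still open, it means among the compounds named here.

Values in an ADME assay on MRC5 cells (Homo sapiens) for inhibition, with a stated time of 72 h; a lower number here means that less compound is needed, a higher number that more compound is needed for the effect:
- compound 1 `COc1cccc(OC)c1C(=O)Nc1c[nH]nc1C(=O)N[C@H]1CC[C@H](OC)CC1`: 31000 nM
- compound 2 `COc1cccc(OC)c1C(=O)Nc1c[nH]nc1C(=O)NCc1ccccn1`: > 50000 nM (a limit)
- compound 3 `COc1cccc(OC)c1C(=O)Nc1c[nH]nc1C(=O)NCCN1CCCC1`: > 50000 nM (a limit)
- compound 4 `COc1cccc(OC)c1C(=O)Nc1c[nH]nc1C(=O)NC1CCC(C)CC1`: not yet measured

Compound 3 has no number, only a limit, and stands at the limit of > 50000 nM in this assay, at which 2 of the 3 values shown sit. The change to compound 4 is 4-methylcyclohexyl in place of 2-(pyrrolidin-1-yl)ethyl on an amide-type nitrogen.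

Two measured steps at this amide-type nitrogen bear on it: an at least 1.6-fold higher number from compound 1 to compound 3 (0.20 log units; that floor lies within the scatter) and an at least 1.6-fold higher number from compound 1 to compound 2 (0.20 log units; that floor lies within the scatter). Both are bounded on one side only, so neither gives a true size. The closest guide is compound 1 at 31000 nM, whose 4-methoxycyclohexyl is the nearest measured group to the entering 4-methylcyclohexyl. A lower number is therefore expected on leaving the 2-(pyrrolidin-1-yl)ethyl group, though a result at the limit remains possible. The expected change is an at least 2.2-fold lower number from compound 3 to compound 4 (0.35 log units; beyond the scatter). For compound 4 the estimated value is 22000 nM, with an expected range of 8000 nM to 50000 nM.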

Compound 4, half-maximal effective concentration: 45000 nM
Beside the measured number, compound 4's estimate is 2.0-fold (0.31 log units) below it; the range from low to high includes it.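

In this assay, the exchange of 4-methoxycyclohexyl for 4-methylcyclohexyl on the amide-type nitrogen is a 1.5-fold higher number from compound 1 to compound 4 (0.16 log units; within the scatter), so the two substituted cyclohexyl compounds cannot be told apart. Against the other two groups, the change reads as an at least 1.1-fold lower number from compound 3 to compound 4 (0.04 log units; that floor lies within the scatter) and as an at least 1.1-fold lower number from compound 2 to compound 4 (0.04 log units; that floor lies within the scatter), and neither floor establishes a separation of compound 4 from these compounds. Both steps start from a limit of the assay rather than a number: the limit of > 50000 nM in this assay, at which 2 of the 4 values shown sit.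

As far as these compounds go, the true size of these two steps remains open, as does whether the cyclohexyl compounds really separate from the (pyridin-2-yl)methyl and 2-(pyrrolidin-1-yl)ethyl compounds. Also open, from the compounds shown here alone, is whether unsubstituted cyclohexyl, or a hydroxyl or primary amine in place of the methyl of 4-methylcyclohexyl, would read any differently.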